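Two Chloro Groups on a Core That Shows Only Limits

The compounds below may be only part of what the source reports. "The series", "measured", "known", "first", "only" and "open" are said of these compounds alone.

Of the compounds shown here, three sharing one core have been tested in an assay on MCF7 cells for inhibition of Serine-protein kinase ATM (Homo sapiens), read by immunofluorescence, with a stated time of 1 h; a lower number here means a stronger inhibitor, a higher number a weaker inhibitor. Compound 1 `Nc1nc(-c2ccccc2)nn1-c1ncnc2ccccc12` carries a phenyl group; in this assay compound 1 gives > 40000 nM, which is a limit of the assay and not a number. Compound 2 `Nc1nc(-c2ccccn2)nn1-c1ncnc2ccccc12` is the pyridin-2-yl counterpart; compound 2 gives > 40000 nM, again a limit. Compound 3 `Nc1nc(-c2ccccc2)nn1-c1ncnc2cc(Cl)ccc12` bears a chloro group on the core; compound 3 gives > 40000 nM, also a limit. The step that the two limits leave unreadable from compound 1 to compound 2 and the step that the two limits leave unreadable from compound 1 to compound 3 therefore cannot be sized. Compound 3 thus stands at the limit together with the other two, as the limit of > 40000 nM in this assay, at which 3 of the 3 values shown sit, records. Compound 4 `Nc1nc(-c2ccc(Cl)cc2)nn1-c1ncnc2cc(Cl)ccc12` differs from compound 3 by chloro in place of hydrogen on an aromatic carbon. Within the data shown here, no measured step reads on this change; every value shown is a limit, and none gives a direction. Compound 4 is therefore expected to remain at the limit, a step that the limit leaves unreadable from compound 3 to compound 4 that cannot be judged against the scatter. The estimate for compound 4 is 60000 nM, with a range from 15000 nM to 300000 nM.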

Compound 4, half-maximal inhibitory concentration: > 40000 nM
Compound 4: no number, only a limit; the forecaster's own chance of this, stated with the estimate: 85%; the middle value lies beyond the limit too.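

In this assay compound 4 gives > 40000 nM as a limit and not a number. No new step can be read between compound 3 and compound 4. The compounds shown leave open which change to the shared core, if any, would yield a measurable value, since all remain at the limit: the limit of > 40000 nM in this assay, at which 4 of the 4 values shown sit.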